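The compounds below may be only part of what the source reports. "The series", "measured", "known", "first", "only" and "open" are said of these compounds alone.

Measured compounds:
compound 1 `O=C(/C=C/c1ccc(Oc2ncnc3ccc(Cl)cc23)cc1)/C=C/c1c(Cl)cccc1Cl` — 61.7%
compound 2 `O=C(/C=C/c1ccc(Cl)c([N+](=O)[O-])c1)/C=C/c1ccccc1Oc1ncnc2ccc(Cl)cc12` — 70.2%

In a functional assay on MGC-803 cells (Homo sapiens) for inhibition, read by MTT assay, with a stated time of 72 h, tested at 10 uM (on this read-out lower numbers stand for less inhibition of growth and higher numbers for more inhibition of growth at the one concentration tested), compound 1 gives the lower of the two numbers; compound 2 stands higher by an amount that lies within the scatter, so the two show no real difference. Compound 3 `O=C(/C=C/c1ccc(Oc2ncnc3ccc(Cl)cc23)cc1)/C=C/c1cccc(Cl)c1Cl` differs from compound 1 in one place: 2,3-dichlorophenyl in place of 2,6-dichlorophenyl on a double-bonded chain carbon bound to a double-bonded chain carbon. Within the data shown here, no step between two measured compounds is available to size this change, so one expects a shift from compound 1 to compound 3 of a number 0.3 percentage points higher from compound 1 to compound 3 (within the scatter), not beyond the scatter in either direction. Compound 3 is estimated at 62%, between 45% and 78%.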

Compound 3, percent growth inhibition at one concentration: 68.5%
Estimate against measurement, compound 3: 6.5 percentage points below; measured number inside the range.
By their numbers in this assay, from the lowest: compounds 1, 3 and 2 (each within the scatter of the next).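

In this assay, among these compounds, 2,3-dichlorophenyl in place of 2,6-dichlorophenyl on a double-bonded chain carbon bound to a double-bonded chain carbon gives a number 6.8 percentage points higher from compound 1 to compound 3 (within the scatter), the first sized step at this position. For this pair, then, rearranging the two chlorines on the ring leaves no difference that stands out from the scatter. Nothing measured here bears on why this is so.

The compounds shown leave open whether a different group on this ring, such as a dimethylamino group or a carboxylic acid, would move the number beyond the scatter.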